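Swapping iodo for nitro in a weakly active amide series

A few compounds are considered here, and "the series" means these few. Any claim that something is new, unique, unknown or untested is made for them only; others in the source may bear on it.

Compound 1 `CC(C)n1ncc2c(C(=O)Nc3cccnc3)cccc21` gives, in a functional assay on PC-3 cells (Homo sapiens) for inhibition, read by MTT assay, with a stated time of 72 h (a lower number here means a stronger inhibitor, a higher number a weaker inhibitor), > 40000 nM, which is a limit of the assay rather than a number. Compound 2 `CC(C)n1ncc2c(C(=O)NC3CCCC3)cccc21` gives 19400 nM. Compound 3 `CC(C)n1ncc2c(C(=O)NCc3cn(-c4ccc(I)cc4)nn3)cccc21` gives > 40000 nM, again a limit of the assay. Compound 4 `CC(C)n1ncc2c(C(=O)NCc3cn(-c4ccc([N+](=O)[O-])cc4)nn3)cccc21` has not yet been measured.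

Compound 3 therefore stands at the limit of > 40000 nM in this assay, at which 2 of the 3 values shown sit, so nothing is known about how far beyond that point it lies. The change from compound 3 to compound 4 is nitro in place of iodo on an aromatic carbon. Going by the values given here, the only step measured so far is an at least 2.0-fold lower number from compound 1 to compound 2 (0.31 log units; beyond the scatter), which swaps cyclopentyl for pyridin-3-yl on the amide nitrogen, a different part of the molecule, so it gives no direct guide to what happens at the phenyl ring of compound 3. Among the compounds with values here, with no step bearing on this change, the expectation is that compound 4 stays close to where compound 3 stands, and the expected step is a step that the limit leaves unreadable from compound 3 to compound 4. Compound 4 is thus estimated at 45000 nM, within a range from 15000 nM to 150000 nM, most likely reported again only as a limit.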

Compound 4, half-maximal inhibitory concentration: > 40000 nM
Compound 4: only a limit was reported (the forecaster's own chance of this, stated with the estimate: 70%); the middle value lies beyond the limit too.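

Compound 3 and compound 4 are both reported only as limits, so no step between them can be read: the limit of > 40000 nM in this assay, at which 3 of the 4 values shown sit.

The compounds shown leave open whether the 4-iodophenyl or the 4-nitrophenyl compound is the stronger inhibitor in this assay, and how far past the limit either one lies.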